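The source may hold more compounds than are shown below. What is called first, only, known or untested is meant among the compounds shown, and "the series" means these compounds.

Measured so far:
Compound 1 `CNc1nc(NCc2ccc(C(=O)Nc3ccc(F)cc3)cc2)c2ccccc2n1` gives 2900 nM in a functional assay on HCT-116 cells (Homo sapiens) for inhibition, read by luminescence and resazurin assay, with a stated time of 3 days; on this read-out higher numbers stand for weaker inhibition and lower numbers for stronger inhibition.
Compound 2 `CCCCNc1nc(NCc2ccc(C(=O)Nc3ccc(F)cc3)cc2)c2ccccc2n1` gives 1400 nM.
Compound 3 `CCCNc1nc(NCc2ccc(C(=O)NC3CCN(Cc4ccc(F)cc4)CC3)cc2)c2cc(C)ccc2n1` gives 1600 nM.

Compound 2 holds the lowest number of the three, but compound 3 sits within the scatter of it; only compound 1 stands beyond the scatter, so compound 2 cannot be set apart from compound 3. Compound 4 `C=CCNc1nc(NCc2ccc(C(=O)Nc3ccc(F)cc3)cc2)c2ccccc2n1` keeps the rest of compound 2 and differs by vinyl in place of propyl on a saturated chain carbon bound to a nitrogen on an aromatic ring. Going by the values given here, the one measured step that bears on this chain is a 2.1-fold lower number from compound 1 to compound 2 (0.32 log units; beyond the scatter), a modest gain on going from hydrogen to propyl. Compound 4 carries a chain between those two lengths with a double bond added, and nothing measured tells what the double bond does. A small loss, within the scatter, is therefore expected, a 1.3-fold higher number from compound 2 to compound 4 (0.11 log units; within the scatter). Compound 4 is estimated at 1800 nM, with a range from 900 nM to 3600 nM.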

Compound 4, half-maximal inhibitory concentration: 14000 nM
For compound 4 the middle estimate is 7.8-fold (0.89 log units) below the measured one; measured number outside the range, above it.
By their numbers in this assay, from the lowest: compounds 2, 3 and 1 (each within the scatter of the next, the first and the last beyond it); then compound 4.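

In this assay, vinyl in place of propyl gives a 10-fold higher number from compound 2 to compound 4 (1.00 log units; beyond the scatter), and vinyl in place of hydrogen gives a 4.8-fold higher number from compound 1 to compound 4 (0.68 log units; beyond the scatter), so this position can lose far more than the earlier gain of a 2.1-fold lower number from compound 1 to compound 2 (0.32 log units; beyond the scatter) suggested. The numbers here do not follow chain size, since compound 4, with its allyl chain, stands beyond the scatter of both compound 1 and compound 2. Nothing available explains this loss. Still open, going by these compounds, is whether the double bond alone carries the loss. Also open, on these data alone, is how a longer chain such as hexyl, or an amine on this chain, would read.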